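Thiophen-3-yl for pyridin-4-yl on the shared core

The compounds below may be only part of what the source reports. "The series", "measured", "known", "first", "only" and "open" are said of these compounds alone.

The series keeps one core bearing a 2-chlorophenyl group and a 4-hydroxyphenyl group, and varies the third substituent. Compound 1 `Oc1ccc(-c2cc(-c3ccccn3)nc(-c3ccccc3Cl)c2)cc1` has no result in a functional assay on T47D cells (Homo sapiens) for cytotoxicity, read by CCK-8 assay and cell counting, with a stated time of 2 days; a lower number here means a stronger inhibitor, a higher number a weaker inhibitor: for compound 1 the entry reads "not determined" (no result reported). Compound 3 `Oc1ccc(-c2cc(-c3ccncc3)nc(-c3ccccc3Cl)c2)cc1` offers no number to stand on either: in this assay compound 3 has "not determined" (no result reported). Compound 2 `Oc1ccc(-c2cc(-c3ccco3)nc(-c3ccccc3Cl)c2)cc1` is the sole anchor: in this assay compound 2 gives 5480 nM. Compound 4 `Oc1ccc(-c2cc(-c3ccsc3)nc(-c3ccccc3Cl)c2)cc1` differs from compound 3 by thiophen-3-yl in place of pyridin-4-yl on an aromatic carbon. Among the compounds with values here, with compound 3 unmeasured, no step can be counted; the change exchanges one ring for another, and the expectation in this assay rests on compound 2 with its 5480 nM, with no shift beyond the scatter in either direction. Compound 4 is accordingly expected at 5000 nM, within 1500 nM to 16000 nM.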

Compound 4, half-maximal inhibitory concentration: 6110 nM
Compound 4: the middle estimate sits 1.2-fold (0.09 log units) below what was measured; low and high end bracket the measured number.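

In this assay the position now has two measured ring substituents, and exchanging furan-2-yl for thiophen-3-yl gives a 1.1-fold higher number from compound 2 to compound 4 (0.05 log units; within the scatter). This position therefore tolerates that ring exchange without a readable change, though the pair says nothing about any other replacement. No measurement here explains this result. The steps from compound 1 and compound 3 cannot be read, so pyridin-4-yl remains unplaced against thiophen-3-yl. Still open, from the compounds shown here alone, is whether a non-aromatic group at this position, such as an aminomethyl or a carboxylic acid, would move the number beyond the scatter.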